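A few compounds are considered here, and "the series" means these few. Any claim that something is new, unique, unknown or untested is made for them only; others in the source may bear on it.

Working notes on the series. Among the compounds with values here, compound 1 `COc1nc(-c2ccccc2F)ccc1[C@@H](c1ccccc1)[C@@](O)(CCN(C)C)c1cccc2ccccc12` gives "nd" (no result reported) in a toxicity assay on HeLa cells (Homo sapiens) for cytotoxicity (on this read-out higher numbers stand for lower toxicity in this test and lower numbers for higher toxicity in this test), that is, no result reported, so compound 2 `COc1ncc(-c2ccccc2)cc1[C@@H](c1ccccc1)[C@@](O)(CCN(C)C)c1cc(F)cc(F)c1` is the only compound with a number: in this assay compound 2 gives 28.8 ug/mL, and nothing sits beside it for comparison. Compound 3 `COc1ncc(-c2ccccc2)cc1[C@@H](c1ccccc1)[C@@](O)(CCN(C)C)c1cccc2ccccc12` remains to be measured. Compound 3 carries naphthalen-1-yl in place of 3,5-difluorophenyl on a saturated chain carbon bound to an oxygen on a saturated carbon and two saturated chain carbons. Within the data shown here, no measured step for such a change exists in this set, so the expected step from compound 2 to compound 3 in this assay is small, a 1.4-fold lower number from compound 2 to compound 3 (0.16 log units; within the scatter), slightly towards higher toxicity but within the usual scatter. For compound 3 the estimated half-maximal cytotoxic concentration in this assay is 20 ug/mL, with a range from 8 ug/mL to 50 ug/mL.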

Compound 3, half-maximal cytotoxic concentration: 30.4 ug/mL
For compound 3 the middle estimate is 1.5-fold (0.18 log units) below the measured one; measured number inside the range.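

In this assay, within the data shown here, naphthalen-1-yl in place of 3,5-difluorophenyl on a saturated chain carbon bound to an oxygen on a saturated carbon and two saturated chain carbons gives a 1.1-fold higher number from compound 2 to compound 3 (0.02 log units; within the scatter) and thus provides the first readable step at this position. Exchanging one aromatic ring for two, with both fluorines gone, produces no change beyond the scatter in this pair. Nothing shown explains why the two compounds read alike. From the compounds shown here alone, whether a carboxylic acid or a primary amine at this position would shift the read-out beyond the scatter remains open.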